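Triazole series: cytotoxicity on PC-12 cells, compounds 1 to 3

The source may report more compounds than this note shows. Statements on the series, on what has been measured and on what is new or still open speak of the compounds shown alone.

Measured so far:
compound 1 `CCc1ccc(-n2nc(-c3ccc(C(F)(F)F)cc3O)nc2-c2ccccc2O)cc1` — 95.4%
compound 2 `N#Cc1ccc(-n2nc(-c3ccc(C(F)(F)F)cc3O)nc2-c2ccccc2O)cc1` — 86.8%

In a functional assay on PC-12 cells (Rattus norvegicus) for cytotoxicity, read by MTT assay, with stated times of 2 h and 24 h, tested at 5 uM (on this read-out higher numbers stand for a stronger effect at the one concentration tested and lower numbers for a weaker effect), compound 2 gives 86.8%. Going by the values given here, this is the lower of the two numbers in hand, but the only neighbour, compound 1, differs by a number 8.6 percentage points lower from compound 1 to compound 2 (within the scatter), so the two values cannot be ranked.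

Compound 3 `Cc1ccc(-n2nc(-c3ccc(C(F)(F)F)cc3O)nc2-c2ccccc2O)c(C)c1` is not yet measured. It differs from compound 2 in one place: 2,4-dimethylphenyl in place of 4-cyanophenyl on an aromatic nitrogen.

Among the compounds with values here, the only step available for comparison is the one from compound 1 to compound 2, where an aromatic carbon substituent was exchanged with a shift of a number 8.6 percentage points lower from compound 1 to compound 2 (within the scatter). That step moved the read-out by less than the usual scatter, and nothing in the data points to a larger effect for the present exchange on the aromatic nitrogen. The expected step from compound 2 to compound 3 in this assay is therefore a number 3.2 percentage points higher from compound 2 to compound 3 (within the scatter), none beyond the scatter. The estimate for compound 3 in this assay is 90%, ranging from 76% to 100%.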

Compound 3, a percentage reported as activity, at one concentration (the size of the read-out at that concentration, not a potency): 93.3%
Beside the measured number, compound 3's estimate is 3.3 percentage points below it; measured number inside the range.
By their numbers in this assay, from the lowest: compounds 2, 3 and 1 (each within the scatter of the next).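

Compounds 1 and 2 differed only in the group on the aromatic carbon of the ring on the nitrogen, whereas compound 3 changes the substitution of that ring itself. In this assay, 2,4-dimethylphenyl in place of 4-cyanophenyl on the aromatic nitrogen gives a number 6.5 percentage points higher from compound 2 to compound 3 (within the scatter), and 2,4-dimethylphenyl in place of 4-ethylphenyl gives a number 2.1 percentage points lower from compound 1 to compound 3 (within the scatter), so a ring with two methyl groups and no nitrile reads the same as both single-substituent rings at this position. No measurement at hand bears on the cause of this result.

As far as these compounds go, whether an amine or a carboxylic acid on this ring would move the read-out beyond the scatter remains open, as does the effect of a chain longer than ethyl. With one concentration per compound, the values also leave potency differences within the series open.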